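A few compounds are considered here, and "the series" means these few. Any claim that something is new, unique, unknown or untested is made for them only; others in the source may bear on it.

The measured compounds:
Compound 1 `COc1ccccc1-c1cccc(S(=O)(=O)N2CCC(N3CCC(C)CC3)CC2)c1`: 21 nM
Compound 2 `Cc1noc(C)c1S(=O)(=O)N1CCC(N2CCC(C)CC2)CC1`: > 5000 nM
Compound 3 `Cc1cc(C)c(S(=O)(=O)N2CCC(N3CCC(CCO)CC3)CC2)c(C)c1`: 19 nM

All three were run in a functional assay on DLD-1 cells (Homo sapiens) for antiproliferative activity, read by CellTiter-Glo, with a stated time of 72 h; a higher number here means a weaker inhibitor, a lower number a stronger inhibitor. Compound 1 gives 21 nM and compound 3 gives 19 nM; these two values lie within the usual scatter of each other, so no order can be read between them. Compound 2 stands apart from both. Its entry of > 5000 nM is a limit of the assay rather than a number, and it is the one entry among the three that sits at that limit (the limit of > 5000 nM in this assay, at which 1 of the 3 values shown sits).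

The next compound to consider is compound 4 `CC1CCN(C2CCN(S(=O)(=O)c3cc(Cl)cc(Cl)c3)CC2)CC1`. It keeps the core of compound 2 and changes only the group on the sulfonyl sulfur: 3,5-dichlorophenyl in place of 3,5-dimethyl-1,2-oxazol-4-yl on a sulfonyl sulfur. Among the measured compounds shown here, no pair of measured compounds differs by exactly this change, so there is no measured step to lean on.

The expectation is a large step toward stronger inhibition, expected as an at least 160-fold lower number from compound 2 to compound 4 (2.22 log units; beyond the scatter), because compound 1 with 21 nM and compound 3 with 19 nM show that this core can reach low values when the sulfonyl carries another group. Compound 4 is therefore estimated at 30 nM, with a range from 8 nM to 200 nM.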

Compound 4, half-maximal inhibitory concentration: 3400 nM
For compound 4 the middle estimate is 110-fold (2.05 log units) below the measured one; the whole stated range lies below it.
By their numbers in this assay, from the lowest: compounds 3 and 1 (each within the scatter of the next); then compound 4. At a limit, above all of these: compound 2.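

In this assay, placing 3,5-dichlorophenyl in place of 3,5-dimethyl-1,2-oxazol-4-yl on a sulfonyl sulfur gives an at least 1.4-fold lower number from compound 2 to compound 4 (0.16 log units; that floor lies within the scatter). The entry for compound 2 is a limit of the assay and not a number, so the true size of this step cannot be read: the limit of > 5000 nM in this assay, at which 1 of the 4 values shown sits. The new information is that this ring of carbon only is not enough to bring the shared core down to low numbers: compound 4 gives 3400 nM while compound 1, which differs from it only in the group on the sulfonyl sulfur, gives 21 nM.

The compounds shown do not reveal which part of the group on the sulfonyl sulfur of compound 1 goes with its much lower number. Also open, on these data alone, is how the number would respond to other groups on the phenyl ring of compound 4, such as a nitrile, an amine or a carboxylic acid in place of the chlorines.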